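Swapping the aryl partner on a thiophene core

The source may report more compounds than this note shows. Statements on the series, on what has been measured and on what is new or still open speak of the compounds shown alone.

Compound 1 `COc1ccc(-c2ccoc2-c2cc(OC)c(OC)c(OC)c2)cc1O`: 2.4 nM
Compound 2 `COc1cc(-c2cscc2-c2ccc(C)c(F)c2)cc(OC)c1OC`: 310 nM

In a functional assay on SH-SY5Y cells (Homo sapiens) for cytotoxicity, read by MTT assay, with a stated time of 48 h (on this read-out lower numbers stand for stronger inhibition and higher numbers for weaker inhibition), compound 2 holds the highest number of the two, the weaker of the pair, while compound 1 sits far lower. Compound 3 `COc1ccc(-c2cscc2-c2cc(OC)c(OC)c(OC)c2)cc1` changes compound 2 in one place: 4-methoxyphenyl in place of 3-fluoro-4-methylphenyl on an aromatic carbon. For the measured compounds named here, no measured step for this change exists, so the expectation rests on compound 1, which carries a methoxy-bearing aryl group and gives 2.4 nM. Compound 3 is expected to move toward that lower number, a step of a 10-fold lower number from compound 2 to compound 3 (1.01 log units; beyond the scatter) in this assay. For compound 3 the estimate is 30 nM, within 5 nM to 200 nM.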

Compound 3, half-maximal inhibitory concentration: 480 nM
Estimate against measurement, compound 3: 16-fold (1.20 log units) below; the measured number lies above the stated range.
By their numbers in this assay, from the lowest: compound 1; then compounds 2 and 3 (each within the scatter of the next).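

In this assay, placing 4-methoxyphenyl instead of 3-fluoro-4-methylphenyl on the aromatic carbon of the five-membered aromatic ring with 1 sulfur gives a 1.5-fold higher number from compound 2 to compound 3 (0.19 log units; within the scatter) and so does not separate the two aryl groups. At this position, the hydrogen-bond acceptor counted on the entering group comes with no change beyond the scatter. No measured evidence bears on this result. From the compounds shown here alone, whether an amine or a carboxylic acid on this aryl group would change the number remains open. Going by these compounds, compound 1 differs from compound 3 in more than one place, so the source of its much lower number also remains open.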